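A few compounds are considered here, and "the series" means these few. Any claim that something is new, unique, unknown or untested is made for them only; others in the source may bear on it.

Measured so far:
compound 1 `O=C(Nc1cccc(-c2oc3cc(-c4ccc(F)cc4)ccc3c(=O)c2O)c1)c1ccc(Cl)cc1` gives 4030 nM
compound 2 `Cc1ccccc1C(=O)Nc1cccc(-c2oc3cc(-c4ccc(F)cc4)ccc3c(=O)c2O)c1` gives 9900 nM
compound 3 `O=C(Nc1cccc(-c2oc3cc(-c4ccc(F)cc4)ccc3c(=O)c2O)c1)c1ccc(Cl)nc1` gives 7550 nM

In a functional assay on HCC1937 cells (Homo sapiens) for antiproliferative activity, read by CCK-8 assay, with a stated time of 72 h (a higher number here means a weaker inhibitor, a lower number a stronger inhibitor), compound 2 has the highest number of the three, with compound 3 within the scatter of it and compound 1 separated by a 2.5-fold higher number from compound 1 to compound 2 (0.39 log units; beyond the scatter). Compound 4 `N#Cc1ccc(C(=O)Nc2cccc(-c3oc4cc(-c5ccc(F)cc5)ccc4c(=O)c3O)c2)cc1` differs from compound 2 in one place: 4-cyanophenyl in place of 2-methylphenyl on a carbonyl carbon. Within the data shown here, the only step that bears on this change is the one from compound 1 to compound 2, where the reverse exchange on the same carbonyl carbon gave a 2.5-fold higher number from compound 1 to compound 2 (0.39 log units; beyond the scatter); the step of a 1.3-fold lower number from compound 2 to compound 3 (0.12 log units; within the scatter) stayed within the scatter. A modest fall in the number, partly undoing that step, is therefore expected, a 1.8-fold lower number from compound 2 to compound 4 (0.26 log units; within the scatter). Compound 4 is estimated at 5500 nM, within the range 2500 nM to 12000 nM.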

Compound 4, half-maximal inhibitory concentration: 2990 nM
Compound 4: middle estimate off by 1.8-fold (0.26 log units), on the high side; the range from low to high includes it.
By their numbers in this assay, from the lowest: compounds 4, 1, 3 and 2 (each within the scatter of the next, the first and the last beyond it).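

In this assay this place on the carbonyl carbon does respond to the group it carries: 4-cyanophenyl gives a 3.3-fold lower number from compound 2 to compound 4 (0.52 log units; beyond the scatter) in place of 2-methylphenyl and a 2.5-fold lower number from compound 3 to compound 4 (0.40 log units; beyond the scatter) in place of 6-chloropyridin-3-yl. Cyano in place of chloro on the aromatic carbon gives a 1.3-fold lower number from compound 1 to compound 4 (0.13 log units; within the scatter) and so separates neither compound. No measurement here explains these differences. Going by these compounds, whether a phenyl ring carrying an amine or a carboxylic acid, or a saturated ring such as cyclohexyl, would keep these numbers stays open.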